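Two methoxy groups on the phenyl ester of a sulfonate

The compounds below may be only part of what the source reports. "The series", "measured", "known", "first", "only" and "open" are said of these compounds alone.

Compound 1 `COc1cccc(OS(=O)(=O)c2ccc(N3CCN(C)C3=O)cc2)c1` gives 2500 nM in a functional assay on HT-29 cells (Homo sapiens) for antiproliferative activity, read by sulforhodamine B assay, with a stated time of 48 h; on this read-out higher numbers stand for weaker inhibition and lower numbers for stronger inhibition. Compound 2 `COc1cc(OC)cc(OS(=O)(=O)c2ccc(N3CCN(C)C3=O)cc2)c1` differs by methoxy in place of hydrogen on an aromatic carbon and gives 190 nM, so the step of a 13-fold lower number from compound 1 to compound 2 (1.12 log units; beyond the scatter) is large. Compound 3 `CCCN1CCN(c2ccc(S(=O)(=O)Oc3cccc(OC)c3)cc2)C1=O` differs from compound 1 by ethyl in place of hydrogen on a saturated chain carbon bound to an amide-type nitrogen in a ring. In this assay compound 3 gives 25000 nM, the step of a 10-fold higher number from compound 1 to compound 3 (1.00 log units; beyond the scatter) going the other way. Compound 4 `CCCN1CCN(c2ccc(S(=O)(=O)Oc3ccc(OC)c(OC)c3)cc2)C1=O` is not yet measured; it differs from compound 3 by methoxy in place of hydrogen on an aromatic carbon. Among the measured compounds shown here, this is the same kind of change as the one from compound 1 to compound 2, but the surroundings differ: there the entering methoxy sat meta to a large group and meta to a methoxy group, here it sits ortho to a methoxy group and para to a large group. Because a 13-fold lower number from compound 1 to compound 2 (1.12 log units; beyond the scatter) was large, a step in the same direction is expected, but a somewhat smaller one, estimated as a 5.0-fold lower number from compound 3 to compound 4 (0.70 log units; beyond the scatter). Compound 4 is therefore expected to give about 5000 nM, with a likely range from 1500 nM to 20000 nM.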

Compound 4, half-maximal inhibitory concentration: 14000 nM
Beside the measured number, compound 4's estimate is 2.8-fold (0.45 log units) below it; measured number inside the range.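

Adding methoxy to the core of compound 3 gives only a 1.8-fold lower number from compound 3 to compound 4 (0.25 log units; within the scatter) in this assay, so the large gain seen on the core of compound 1 does not carry over unchanged: the same change on two cores in this assay, a 13-fold lower number (1.12 log units; beyond the scatter) from compound 1 to compound 2 and a 1.8-fold lower number (0.25 log units; within the scatter) from compound 3 to compound 4, 7.4-fold (0.87 log units) apart, beyond the scatter of two such steps

This does not show what sets the two steps apart, as two things differ at once. Here the entering methoxy sits ortho to a methoxy group and para to a large group, a different place from the one it takes in compound 2, and the core of compound 3 also carries ethyl in place of a hydrogen of the core of compound 1.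

From the compounds shown here alone, it remains open whether methoxy placed as in compound 2 would give a large step on the core of compound 3. Going by these compounds, it is also open how a hydroxy group or an amine would compare with methoxy at the new place.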